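The source may report more compounds than this note shows. Statements on the series, on what has been measured and on what is new or still open speak of the compounds shown alone.

Measured so far in an assay on cells for positive allosteric modulation of Cystic fibrosis transmembrane conductance regulator variant G551D (Homo sapiens), with stated times of 10 min and 2 min, in the presence of a further agent that is not named here; on this read-out higher numbers stand for an effect only at larger amounts of compound and lower numbers for an effect already at smaller amounts:

Compound 1 `CC1(C)Cc2c(sc(NC(=O)C3(CO)CC3)c2C(N)=O)C(C)(C)O1`: 1320 nM
Compound 2 `CC(C)(C)CC(O)C(=O)Nc1sc2c(c1C(N)=O)CC(C)(C)OC2(C)C`: 981 nM
Compound 3 `CC1(C)Cc2c(sc(NC(=O)c3[nH]ncc3Cl)c2C(N)=O)C(C)(C)O1`: 81 nM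

Compound 3 stands lowest of the three numbers in this assay. Its nearest neighbour is compound 2, and the step is a 12-fold lower number from compound 2 to compound 3 (1.08 log units; beyond the scatter); the step from compound 1 is a 16-fold lower number from compound 1 to compound 3 (1.21 log units; beyond the scatter). Both steps exchange a non-aromatic group on the carbonyl carbon for the five-membered aromatic ring with 2 hetero atoms, and both lie beyond the scatter. Between compound 1 and compound 2 the change is a 1.3-fold lower number from compound 1 to compound 2 (0.13 log units; within the scatter), so the two non-aromatic groups are not separated here.

Compound 4 `CC1(C)Cc2c(sc(NC(=O)c3cc(C(F)(F)F)n[nH]3)c2C(N)=O)C(C)(C)O1` differs from compound 3 by a group of 9 heavy atoms (4 carbon, 2 nitrogen, 3 fluorine; one five-membered aromatic ring with 2 hetero atoms) in place of a group of 6 heavy atoms (3 carbon, 2 nitrogen, 1 chlorine; one five-membered aromatic ring with 2 hetero atoms), on a carbonyl carbon. Among the compounds with values here, no measured step keeps the five-membered aromatic ring with 2 hetero atoms and varies only its substituent; the two large steps into compound 3 bear on the presence of that ring, which compound 4 retains. In the absence of a step of the same kind, the expectation for this assay is a change of no more than the usual scatter, with the wider range of the estimate taking in a modest shift in either direction. Compound 4 is expected at 120 nM, between 30 nM and 500 nM, which as a step means an expected 1.5-fold higher number from compound 3 to compound 4 (0.17 log units; within the scatter).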

Compound 4, half-maximal effective concentration: 130 nM
Compound 4: the middle estimate sits 1.1-fold (0.03 log units) below what was measured, within the range that was stated.
By their numbers in this assay, from the lowest: compounds 3 and 4 (each within the scatter of the next); then compounds 2 and 1 (each within the scatter of the next).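

In this assay, within the data shown here, the step of a 1.6-fold higher number from compound 3 to compound 4 (0.21 log units; within the scatter) is the first that keeps a five-membered aromatic ring with 2 hetero atoms on the carbonyl carbon while the group around it changes, and at this position it does not separate the chlorine-bearing group from 3-(trifluoromethyl)-1H-pyrazol-5-yl. Among these compounds, the gap to the non-aromatic groups no longer rests on compound 3 alone: a 7.5-fold lower number from compound 2 to compound 4 (0.88 log units; beyond the scatter) and a 10-fold lower number from compound 1 to compound 4 (1.01 log units; beyond the scatter) both lie beyond the scatter and point the same way as the steps into compound 3, and no compound of the four goes against this. No measurement on these compounds accounts for either the gap or the lack of separation.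

Among groups on this ring, it remains open whether a methyl, an amine or a carboxylic acid in place of the trifluoromethyl would stay close to these two numbers, and whether a phenyl ring on the carbonyl carbon would match the five-membered rings. From the compounds shown here alone, all four compounds carry the same core, so whether the gap between aromatic and non-aromatic groups holds on a different core also remains open.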